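This account rests on a few compounds, and the source may have more. Where it says the series, first, only, none or still open, it means among the compounds named here.

Compound 3 `CCN(CC)C/C=C/C(=O)Nc1cc2c(N3CCCc4ccccc43)ncnc2cc1O[C@@H]1CCOC1` is one of three amides that share a core and differ only in the group on the chain beside the amide. In a functional assay on PC-3 cells (Homo sapiens) for antiproliferative activity, read by MTT assay, with a stated time of 72 h (on this read-out higher numbers stand for weaker inhibition and lower numbers for stronger inhibition), compound 3 gives 4270 nM, the second highest of the three numbers. Its nearest neighbour is compound 2 `CN(C)C/C=C/C(=O)Nc1cc2c(N3CCCc4ccccc43)ncnc2cc1O[C@@H]1CCOC1`, which in this assay gives 4170 nM; the step between them, a 1.0-fold higher number from compound 2 to compound 3 (0.01 log units; within the scatter), is within the scatter. The furthest is compound 1 `CC(C)/C=C/C(=O)Nc1cc2c(N3CCCc4ccccc43)ncnc2cc1O[C@@H]1CCOC1`, which gives 8510 nM, and the step of a 2.0-fold lower number from compound 1 to compound 3 (0.30 log units; within the scatter) is within the scatter as well, whereas the step of a 2.0-fold lower number from compound 1 to compound 2 (0.31 log units; beyond the scatter) is modest and beyond it.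

Compound 4 `O=C(/C=C/CN1CCCC1)Nc1cc2c(N3CCCc4ccccc43)ncnc2cc1O[C@@H]1CCOC1` carries pyrrolidin-1-yl in place of diethylamino on a saturated chain carbon bound to a double-bonded chain carbon. Going by the values given here, of the measured steps, only the one from compound 2 to compound 3 changes the group at this place, exchanging one amine substituent for another, and that step was a 1.0-fold higher number from compound 2 to compound 3 (0.01 log units; within the scatter), within the scatter. Nothing measured here separates a ring-closed amine from an open one. Compound 4 is therefore expected to show no step beyond the scatter, with the estimated change a 1.1-fold lower number from compound 3 to compound 4 (0.03 log units; within the scatter). For compound 4 the expected value in this assay is 4000 nM, estimated to lie between 2000 nM and 8500 nM.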

Compound 4, half-maximal inhibitory concentration: 5780 nM
Compound 4: middle estimate off by 1.4-fold (0.16 log units), on the low side, within the range that was stated.
By their numbers in this assay, from the lowest: compounds 2, 3, 4 and 1 (each within the scatter of the next, the first and the last beyond it).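

Pyrrolidin-1-yl brings a five-membered non-aromatic ring to the saturated chain carbon bound to a double-bonded chain carbon, a place that had carried only open-chain amines, yet in this assay neither a 1.4-fold higher number from compound 3 to compound 4 (0.13 log units; within the scatter) nor a 1.4-fold higher number from compound 2 to compound 4 (0.14 log units; within the scatter) lies beyond the scatter, so the three amines in compounds 2, 3 and 4 are not told apart. The comparison with the isopropyl compound is also within the scatter, at a 1.5-fold lower number from compound 1 to compound 4 (0.17 log units; within the scatter) in this read-out, so the step beyond the scatter from compound 1 to compound 2 stays confined to that one pair, and compounds 3 and 4 do not share it. No evidence is available that accounts for any of these numbers.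

The compounds shown leave open whether a six-membered ring amine such as piperidine, or a ring with a second hetero atom such as morpholine or piperazine, would stay within the scatter of these amines at this place. They also leave open what a primary amine, or a longer chain carrying the pyrrolidin-1-yl ring, would do to the number.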